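A few compounds are considered here, and "the series" means these few. Any claim that something is new, unique, unknown or untested is made for them only; others in the source may bear on it.

Compound 1 `CC(C)(C)n1c(=O)n(Cc2cc3cc(Cl)ccc3n2CCCS(C)(=O)=O)c2cnccc21` and compound 2 `N#CCCCn1c(Cn2c(=O)n(-c3ccncn3)c3ccncc32)cc2cc(Cl)ccc21` share one core. In an ADME assay on HeLa cells (Homo sapiens) for cytotoxicity, read by ATP content, with a stated time of 3 days (a lower number here means that less compound is tolerated, a higher number that more compound is tolerated), compound 1 gives > 50000 nM, which is a limit of the assay rather than a number. Compound 2 gives > 50000 nM in this assay, again a limit. Where compound 1 stands is therefore known only as far as that limit reaches, the whole picture so far being (the limit of > 50000 nM in this assay, at which 2 of the 2 values shown sit). Compound 3 `CC(C)n1c(=O)n(Cc2cc3cc(Cl)ccc3n2CCCS(C)(=O)=O)c2cnccc21` has not been measured. It differs from compound 1 by hydrogen in place of methyl on a saturated chain carbon bound to an aromatic nitrogen and two saturated chain carbons. Within the data shown here, with no measured step to set a size, and both known values sitting at the limit, no change beyond the scatter is expected in this assay. The expected step that the limit leaves unreadable from compound 1 to compound 3 is accordingly small. Compound 3 is estimated at 60000 nM, within 25000 nM to 150000 nM, most likely once more reported only as a limit.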

Compound 3, half-maximal cytotoxic concentration: > 50000 nM
Compound 3 was reported as a limit; the forecaster's own chance of this, stated with the estimate: 80%; the middle value is on the limit's open side.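

Compound 3, like compound 1, is reported only as a limit, so no step can be read between the two: the limit of > 50000 nM in this assay, at which 3 of the 3 values shown sit. The compounds shown leave open whether this assay would register any difference between tert-butyl and isopropyl, and where any of these compounds would reach a measured value.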